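This account rests on a few compounds, and the source may have more. Where it says the series, first, only, none or still open, it means among the compounds named here.

In a functional assay on MCF7 cells (Homo sapiens) for cytotoxicity, read by MTT assay, with a stated time of 72 h (on this read-out lower numbers stand for stronger inhibition and higher numbers for weaker inhibition), compound 1 `COc1ccc(C=C2C(=O)N(c3ccc(Cl)cc3)N(c3ccc(Cl)cc3)C2=O)cc1` gives > 128000 nM, which is a limit of the assay and not a number. Compound 2 `O=C1C(=Cc2ccc(Cl)cc2Cl)C(=O)N(c2ccc(Cl)cc2)N1c1ccc(Cl)cc1` gives > 128000 nM, again only a limit. Compound 2 therefore has no number of its own, and the picture so far is the limit of > 128000 nM in this assay, at which 2 of the 2 values shown sit. Compound 3 `O=C1C(=Cc2ccccc2)C(=O)N(c2ccc(Cl)cc2)N1c1ccc(Cl)cc1` differs from compound 2 at a single place: phenyl in place of 2,4-dichlorophenyl on a double-bonded chain carbon bound to a double-bonded ring carbon. For the measured compounds named here, the one measured step at that same place is a step that the two limits leave unreadable from compound 1 to compound 2, and it offers no size to carry over. With nothing readable to build on, no step beyond the scatter is expected in this assay, and no direction can be favoured. The expected change is a number no higher from compound 2 to compound 3 (the limit leaves the size open). For compound 3 the estimated value is 128000 nM, within an expected range of 50000 nM to 256000 nM, and a further limit would be no surprise.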

Compound 3, half-maximal inhibitory concentration: 20200 nM
Beside the measured number, compound 3's estimate is 6.3-fold (0.80 log units) above it, and the stated range ends above it.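

In this assay, the position proves able to move the read-out: phenyl in place of 2,4-dichlorophenyl gives an at least 6.3-fold lower number from compound 2 to compound 3 (0.80 log units; beyond the scatter), and hydrogen in place of methoxy on an aromatic carbon gives an at least 6.3-fold lower number from compound 1 to compound 3 (0.80 log units; beyond the scatter). On these data alone, each of these steps starts from a limit of the assay, and its full size stays open. The step between compound 1 and compound 2 cannot be read, and those two compounds alone had shown only a limit, not a number: the limit of > 128000 nM in this assay, at which 2 of the 3 values shown sit.

Whether the lower number needs both chlorines gone or only one stays open, since no compound shown carries a single chlorine on that ring. What an amine or a carboxylic acid on the phenyl would give at this place is also unknown from the compounds shown.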